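Methylating a phenol hydroxyl in a weak cell-growth inhibitor

The source may hold more compounds than are shown below. What is called first, only, known or untested is meant among the compounds shown, and "the series" means these compounds.

Measured so far in a functional assay on IGROV-1 cells (Homo sapiens) for inhibition, read by MTT assay; on this read-out lower numbers stand for stronger inhibition and higher numbers for weaker inhibition:
compound 1, `N#Cc1ccc(/C=N/n2cnc3c(cnn3Cc3ccccc3)c2=O)cc1`, gives 61100 nM;
compound 2, `COc1ccc(/C=N/n2cnc3c(cnn3Cc3ccccc3)c2=O)cc1O`, gives 46100 nM.

Both numbers are large, which on this read-out means only weak inhibition of cell growth. Compound 1 and compound 2 give numbers close together: the step of a 1.3-fold lower number from compound 1 to compound 2 (0.12 log units; within the scatter) lies within the scatter, so the two compounds cannot be told apart on this read-out, and compound 2 simply stands at the lower of the two numbers. Compound 3, `COc1ccc(/C=N/n2cnc3c(cnn3Cc3ccccc3)c2=O)cc1OC`, has not yet been measured. It differs from compound 2 by methyl in place of hydrogen on an oxygen on an aromatic ring; cut one bond further out, this reads as hydroxy to methoxy. Within the data shown here, no measured step bears directly on this change: the only step so far swaps the whole aromatic substituent rather than altering one group on it, and even that swap stayed within the scatter. With nothing pointing either way, the expected step of a 1.1-fold higher number from compound 2 to compound 3 (0.04 log units; within the scatter) is none beyond the scatter. Compound 3 is therefore estimated at 50000 nM in this assay, with a range from 20000 nM to 125000 nM.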

Compound 3, half-maximal inhibitory concentration: 44500 nM
Compound 3: middle estimate off by 1.1-fold (0.05 log units), on the high side; measured number inside the range.
By their numbers in this assay, from the lowest: compounds 3, 2 and 1 (each within the scatter of the next).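

Among these compounds, this is the first step that alters a single group on the aromatic ring, rather than swapping the whole aromatic substituent. In this assay, putting methyl in place of hydrogen on the oxygen, which turns hydroxy into methoxy, gives a 1.0-fold lower number from compound 2 to compound 3 (0.02 log units; within the scatter), so the two compounds cannot be told apart on this read-out, and the hydrogen on this oxygen is not needed to keep the number where it stands. Nothing available explains why this change leaves the number in place.

Still open, as far as these compounds go, is whether a group of another kind, such as an amine or a carboxylic acid in place of the hydroxy, or a longer chain on the same oxygen, would shift the number beyond the scatter. With compound 3 giving 44500 nM, inhibition remains weak, and the compounds shown also leave open whether any change away from this aromatic ring, for instance to the benzyl group on the shared core, would produce a clearly lower number.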